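This account rests on a few compounds, and the source may have more. Where it says the series, first, only, none or still open, it means among the compounds named here.

Measured in an ADME assay on HEK-293T cells (Homo sapiens) for cytotoxicity, read by CCK-8 assay, with a stated time of 48 h; on this read-out higher numbers stand for weaker inhibition and lower numbers for stronger inhibition:
- Compound 1 `O=C(NCCNS(=O)(=O)c1ccc(-c2ccccc2OCc2cccc(O)c2)s1)Nc1cc(Cl)cc(Cl)c1`: > 20000 nM, a limit of the assay
- Compound 2 `O=[N+]([O-])c1ccc(NC(=S)NCCNS(=O)(=O)c2ccc(-c3ccccc3O[C@H]3CC[C@@H](O)CC3)s2)cc1`: 20000 nM

Within the data shown here, compound 2 holds the only true number in this assay, 20000 nM, so it can be ranked against no other measured compound. Compound 3 `O=[N+]([O-])c1ccc(NC(=S)NCCNS(=O)(=O)c2ccc(-c3ccccc3OCc3cccc(O)c3)s2)cc1` has not yet been measured. It differs from compound 2 at one place, 3-hydroxybenzyl in place of 4-hydroxycyclohexyl on an oxygen on an aromatic ring. Compound 1, which also carries 3-hydroxybenzyl, reports only the limit > 20000 nM. Among the measured compounds shown here, no measured step guides this change, so the expected step, no change at the digits printed from compound 2 to compound 3 (within the scatter), is estimated to stay within the usual scatter, with no direction favoured. Compound 3 is expected at 20000 nM, within an estimated range of 9000 nM to 40000 nM.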

Compound 3, half-maximal inhibitory concentration: > 20000 nM
Compound 3: no number, only a limit; the forecaster's own chance of this, stated with the estimate: 50%; the middle value lies on the limit itself.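

In this assay, 3-hydroxybenzyl in place of 4-hydroxycyclohexyl on an oxygen on an aromatic ring gives a number no lower from compound 2 to compound 3 (the limit leaves the size open), so this position accepts the six-membered aromatic ring with no drop in the number. The result for compound 3 is a limit, not a number, and the step between compound 1 and compound 3 cannot be read either. The read-out offers little room to separate these compounds: the limit of > 20000 nM in this assay, at which 2 of the 3 values shown sit.

The compounds shown leave open whether a longer chain ending in an amine, or a carboxylic acid, on this oxygen would give a lower number. They also leave open how far the number rises with 3-hydroxybenzyl.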